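Swapping the pyridine ring for a benzene ring at the chain end

The compounds below may be only part of what the source reports. "The series", "measured", "known", "first", "only" and "open" are said of these compounds alone.

Of the compounds shown here, three with a shared core have been measured in an assay for positive allosteric modulation of metabotropic glutamate receptor 2 (Rattus norvegicus); a higher number here means that more compound is needed for the effect, a lower number that less compound is needed. Compound 1 `Cc1ncc(OCCCCOc2ccc(C(=O)CC(C)(C)C)c(O)c2C)cc1C(=O)O` gives 28 nM and stands lowest of the three. Compound 2 `Cc1c(OCCCCOc2cncc(C(=O)O)c2)ccc(C(=O)CC(C)(C)C)c1O` gives 490 nM, and compound 3 `Cc1ccc(OCCCCOc2ccc(C(=O)CC(C)(C)C)c(O)c2C)cc1C(=O)O` gives 210 nM. Removing one methyl from an aromatic carbon raises the number sharply: an 18-fold higher number from compound 1 to compound 2 (1.24 log units; beyond the scatter). Replacing the 5-carboxy-6-methylpyridin-3-yl group of compound 1 with a 3-carboxy-4-methylphenyl group also raises it, though less: a 7.5-fold higher number from compound 1 to compound 3 (0.88 log units; beyond the scatter). Between compound 2 and compound 3 the step is a 2.3-fold lower number from compound 2 to compound 3 (0.37 log units; beyond the scatter).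

Compound 4 `Cc1ccc(C(=O)O)cc1OCCCCOc1ccc(C(=O)CC(C)(C)C)c(O)c1C` has not yet been measured. It differs from compound 1 in one place: 5-carboxy-2-methylphenyl in place of 5-carboxy-6-methylpyridin-3-yl on an oxygen on a saturated carbon. Among the compounds with values here, the change most like it is the one from compound 1 to compound 3, where the pyridine ring also became a benzene ring carrying a carboxy and a methyl group; here the two groups sit in a different arrangement on that ring, for which no measured step exists. The step of a 7.5-fold higher number from compound 1 to compound 3 (0.88 log units; beyond the scatter) therefore guides the expectation, with added uncertainty from the changed arrangement. Compound 4 is expected to give a higher number than compound 1, roughly an 11-fold higher number from compound 1 to compound 4 (1.03 log units; beyond the scatter), and its estimated value is 300 nM, within a range of 80 nM to 1200 nM.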

Compound 4, half-maximal effective concentration: 512 nM
Beside the measured number, compound 4's estimate is 1.7-fold (0.23 log units) below it; low and high end bracket the measured number.
By their numbers in this assay, from the lowest: compound 1; then compound 3; then compounds 2 and 4 (each within the scatter of the next).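

The carboxy and methyl groups stay on a carbon-only ring between compound 3 and compound 4, and only their arrangement changes, yet the result is a 2.4-fold higher number from compound 3 to compound 4 (0.39 log units; beyond the scatter) beyond the scatter, so the arrangement of these two groups matters at this position on its own. The 5-carboxy-2-methylphenyl group also gives a large loss against the group it replaces, with an 18-fold higher number from compound 1 to compound 4 (1.26 log units; beyond the scatter) as the full step, which shows that a benzene ring carrying these same two groups does not by itself come close to compound 1. The last step, a 1.0-fold higher number from compound 2 to compound 4 (0.02 log units; within the scatter) within the scatter, leaves compound 2 and compound 4 indistinguishable here, even though one has a pyridine ring without the methyl group and the other a benzene ring with it.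

Still open, on these data alone, is whether a chlorine in place of the methyl group, or an amide in place of the carboxylic acid, would keep the number near that of compound 1 on either ring. The data shown offer no evidence that explains why the arrangement or the ring changes the number.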